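This account rests on a few compounds, and the source may have more. Where it says the series, first, only, none or still open, it means among the compounds named here.

Of the compounds shown here, three have so far been measured in an assay on CHO cells for displacement of a labelled ligand from adenosine receptor A3 (Homo sapiens), read by scintillation counting, with a stated time of 120 min, tested at 10 uM; on this read-out higher numbers stand for more inhibition at the one concentration tested (going by the name of the read-out) and lower numbers for less inhibition. Compound 1 `Nc1scc(CN2CCN(c3cccnc3)CC2)c1C(=O)c1ccc(Cl)cc1` gives 0%. Compound 2 `Nc1scc(CN2CCN(c3cccc(F)c3)CC2)c1C(=O)c1cccc(C(F)(F)F)c1` gives 0%. Compound 3 `Nc1scc(CN2CCN(C3CCCCCC3)CC2)c1C(=O)c1ccc(Cl)cc1` gives 0%, level with both of them at the digits shown. For the measured compounds named here, the one measured step that changes a single place, no change at the digits printed from compound 1 to compound 3 (within the scatter), stayed within the scatter. Compound 4 `Nc1scc(CN2CCN(c3c(Cl)cccc3Cl)CC2)c1C(=O)c1ccc(Cl)cc1` has not been measured; it differs from compound 3 by 2,6-dichlorophenyl in place of cycloheptyl on an amine nitrogen in a ring. Going by the values given here, the only step that touches the same place, no change at the digits printed from compound 1 to compound 3 (within the scatter), was flat, and all three measured compounds sit at the same reading, so no step beyond the scatter is expected in this assay: the estimated step is no change at the digits printed from compound 3 to compound 4 (within the scatter). Compound 4 is therefore expected to give 0%, with a range from -10% to 10%.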

Compound 4, a percentage reported as inhibition, at one concentration (the size of the read-out at that concentration, not a potency): 1%
Beside the measured number, compound 4's estimate is 1 percentage points below it, and the stated range covers the measured number.
By their numbers in this assay, from the lowest: compounds 1, 2, 3 and 4 (each within the scatter of the next).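

In this assay, placing 2,6-dichlorophenyl on the amine nitrogen in the ring gives a number 1 percentage points higher from compound 3 to compound 4 (within the scatter) and a number 1 percentage points higher from compound 1 to compound 4 (within the scatter), so this chlorine-bearing aromatic ring reads the same as the cycloheptyl and pyridin-3-yl groups it replaces. No supporting data bear on why the reading stays flat here.

From the compounds shown here alone, whether any group at this position can raise the reading remains open, and a carboxylic acid, an amine or a longer chain there would test it. Also open, going by these compounds, is whether changes elsewhere on the shared core would matter more.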